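The source may hold more compounds than are shown below. What is called first, only, known or untested is meant among the compounds shown, and "the series" means these compounds.

Of the compounds shown here, three sharing one core have been measured in a functional assay on HepG2 cells (Homo sapiens) for inhibition, read by MTT assay, with a stated time of 3 days; a lower number here means a stronger inhibitor, a higher number a weaker inhibitor. Compound 1 (`COc1cc(-c2nc3ccccc3s2)ccc1OCC(=O)NNC(=O)CN[C@@H](CS)C(=O)O`) gives 3120 nM, compound 2 (`CCOC(=O)[C@H](CS)NCC(=O)NNC(=O)COc1ccc(-c2nc3ccccc3s2)cc1OC`) gives 3760 nM and compound 3 (`CCOC(=O)[C@H](CCSC)NCC(=O)NNC(=O)COc1ccc(-c2nc3ccccc3s2)cc1OC`) gives 3330 nM. Compound 3 thus stands within the scatter of both other compounds, and no order can be read among the three.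

Compound 4 (`CCOC(=O)[C@@H]1CCCN1CC(=O)NNC(=O)COc1ccc(-c2nc3ccccc3s2)cc1OC`) is derived from compound 3 by a single change: 2-(ethoxycarbonyl)pyrrolidin-1-yl in place of (1-(ethoxycarbonyl)-3-(methylsulfanyl)propyl)amino on a saturated chain carbon bound to a carbonyl carbon. Among the compounds with values here, three measured steps bear on it. The first, at the ester, is a 1.2-fold higher number from compound 1 to compound 2 (0.08 log units; within the scatter). The other two alter the group that is being replaced here, and they are a 1.1-fold higher number from compound 1 to compound 3 (0.03 log units; within the scatter) and a 1.1-fold lower number from compound 2 to compound 3 (0.05 log units; within the scatter). All three stay within the scatter, so this series has so far shown little response in this assay to changes in this part of the molecule.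

Within the data shown here, none of the measured compounds carries a ring at this place, however, and all of them keep the hydrogen on the amine nitrogen, so the data do not directly test the new group. No shift beyond the scatter is expected, and the estimated step is a 1.1-fold higher number from compound 3 to compound 4 (0.02 log units; within the scatter). For compound 4 the estimated value is 3500 nM, with an expected range from 1800 nM to 7000 nM.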

Compound 4, half-maximal inhibitory concentration: 2800 nM
Compound 4: middle estimate off by 1.3-fold (0.10 log units), on the high side, and the stated range covers the measured number.
By their numbers in this assay, from the lowest: compounds 4, 1, 3 and 2 (each within the scatter of the next).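

In this assay, the 2-(ethoxycarbonyl)pyrrolidin-1-yl group brings a five-membered non-aromatic ring to this position, has no hydrogen-bond donor and contains no sulfur, yet the steps to compound 4 all stay within the scatter (a 1.2-fold lower number from compound 3 to compound 4 (0.08 log units; within the scatter); a 1.3-fold lower number from compound 2 to compound 4 (0.13 log units; within the scatter); a 1.1-fold lower number from compound 1 to compound 4 (0.05 log units; within the scatter)). The earlier compounds all kept the amine hydrogen and an open chain, so only now is it shown that this position can take a ring, and lose that hydrogen, without a shift beyond the scatter in this series. No measurement at hand offers an explanation for this flat response.

Going by these compounds, all four numbers still lie within the scatter of one another, so it remains open whether any group on this saturated chain carbon can move the number beyond the scatter. A piperidine ring in place of the pyrrolidine, a free carboxylic acid on the pyrrolidine ring in place of the ethyl ester, or an amide at that same carbonyl could each test whether this insensitivity extends further.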